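The source may hold more compounds than are shown below. What is called first, only, known or untested is meant among the compounds shown, and "the series" means these compounds.

- compound 1 `Cc1ccc(C(=O)c2ccc(OCC(=O)Nc3nc(-c4ccccc4)cs3)c(C)c2)cc1`: 27100 nM
- compound 2 `COc1ccc(-c2csc(NC(=O)COc3ccc(C(=O)c4ccc(C)cc4)cc3C)n2)cc1`: 18700 nM
- compound 3 `Cc1cc(C(=O)c2ccccc2C)ccc1OCC(=O)Nc1nc(-c2ccccc2)cs1`: 23700 nM

These three values come from a functional assay on DLA cells (Mus musculus) for cytotoxicity, read by LDH release, with a stated time of 48 h; a higher number here means a weaker inhibitor, a lower number a stronger inhibitor. There, compound 2, at 18700 nM, cannot be told apart from compound 1 or compound 3, since its gaps to both lie within the usual scatter.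

Compound 4 `COc1ccc(-c2csc(NC(=O)COc3ccc(C(=O)c4cccc(F)c4)cc3C)n2)cc1` keeps the rest of compound 2 and carries 3-fluorophenyl in place of 4-methylphenyl on a carbonyl carbon. The closest guide is another swap at that same carbonyl carbon, 2-methylphenyl in place of 4-methylphenyl, which gave a 1.1-fold lower number from compound 1 to compound 3 (0.06 log units; within the scatter). Methoxy in place of hydrogen on an aromatic carbon gave a 1.4-fold lower number from compound 1 to compound 2 (0.16 log units; within the scatter), but that change is not part of this step. Among the measured compounds shown here, no measured compound carries fluorine, so that part of the change remains untested. With both measured steps this small, no shift beyond the scatter is expected.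

The expected step is a 1.0-fold lower number from compound 2 to compound 4 (0.02 log units; within the scatter).

For compound 4 the estimated value is 18000 nM, with an expected range from 8000 nM to 38000 nM.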

Compound 4, half-maximal inhibitory concentration: 30300 nM
Beside the measured number, compound 4's estimate is 1.7-fold (0.23 log units) below it; measured number inside the range.
By their numbers in this assay, from the lowest: compounds 2, 3, 1 and 4 (each within the scatter of the next).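

In this assay, among the compounds shown here, the first fluorine-bearing group at this carbonyl carbon, 3-fluorophenyl in place of 4-methylphenyl, gives a 1.6-fold higher number from compound 2 to compound 4 (0.21 log units; within the scatter). With the earlier swap at the same carbon, a 1.1-fold lower number from compound 1 to compound 3 (0.06 log units; within the scatter), this shows that two different replacements for 4-methylphenyl, each tested on a different compound, leave the number within the scatter, so neither methyl placement nor this fluorine substitution has a clear effect here. Nothing measured on these compounds speaks to what lies behind the step.

As far as these compounds go, whether an amine or a carboxylic acid on this phenyl ring would move the number beyond the scatter remains open. So does whether 4-fluorophenyl would read any differently from 3-fluorophenyl.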